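This account rests on a few compounds, and the source may have more. Where it says the series, first, only, none or still open, it means among the compounds named here.

Compound 1 `CC(C)=CC(=O)Nc1cccc(Oc2nc(Nc3ccn(C)n3)nc3c2CSCC3)c1`: > 50000 nM, a limit
Compound 2 `C=C(C)C(=O)Nc1cccc(Oc2nc(Nc3ccn(C)n3)nc3c2CSCC3)c1`: > 50000 nM, a limit

In an ADME assay on L02 cells (Homo sapiens) for cytotoxicity, read by MTT assay, with a stated time of 72 h (a lower number here means a stronger inhibitor, a higher number a weaker inhibitor), compound 1 stands only at a limit, > 50000 nM, and has no number. Compound 2 also gives only a limit. For the measured compounds named here, the one measured step, a step that the two limits leave unreadable from compound 1 to compound 2, lies on a carbonyl carbon and gives no size. All the series shows so far is the limit of > 50000 nM in this assay, at which 2 of the 2 values shown sit.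

Compound 3 `CC(C)=CC(=O)Nc1cccc(Oc2nc(Nc3cccc(C#N)c3)nc3c2CSCC3)c1` differs from compound 1 as follows: 3-cyanophenyl in place of 1-methyl-1H-pyrazol-3-yl on a nitrogen on an aromatic ring. Going by the values given here, no measured step bears on this change, so no size carries over. The read-out is expected to stay near the limit, with a modest move toward stronger inhibition possible. The estimated change is an at least 1.4-fold lower number from compound 1 to compound 3 (0.15 log units; that floor lies within the scatter). Compound 3 is estimated at 35000 nM, with an expected range of 10000 nM to 50000 nM.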

Compound 3, half-maximal inhibitory concentration: > 50000 nM
Compound 3 gave a limit, no number (the forecaster's own chance of this, stated with the estimate: 50%); middle value at least 1.4-fold (0.15 log units) from the limit.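

In this assay, for the compounds shown here, compound 3, like compound 1, gives only a limit, so no step between compound 1 and compound 3 can be read. Whether any change in this series yields a readable number remains open: the limit of > 50000 nM in this assay, at which 3 of the 3 values shown sit.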